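The source may report more compounds than this note shows. Statements on the series, on what has been measured and on what is new or still open speak of the compounds shown alone.

In a functional assay on NCI-H1975 cells (Homo sapiens) for cytotoxicity, read by MTT assay, with a stated time of 72 h (on this read-out lower numbers stand for stronger inhibition and higher numbers for weaker inhibition), compound 1 (`C#Cc1cccc(Nc2nc3cnc(Nc4ccc(N5CCN(C)CC5)cc4)nc3n2C2CCCC2)c1`) gives 650 nM and compound 2 (`Cc1cccc(Nc2nc3cnc(Nc4ccc(N5CCN(C)CC5)cc4)nc3n2C2CCCC2)c1`) gives 560 nM, so the two lie within the scatter of each other. Compound 3 (`CN1CCN(c2ccc(Nc3ncc4nc(Nc5cccc(NC(=O)c6ccccc6)c5)n(C5CCCC5)c4n3)cc2)CC1`) carries benzamido in place of methyl on an aromatic carbon, meta to a large group (benzamido in place of methyl on an aromatic carbon). For the measured compounds named here, the only measured step, a 1.2-fold lower number from compound 1 to compound 2 (0.06 log units; within the scatter), exchanges ethynyl for methyl and involves no group like benzamido, so it is a weak guide and no step beyond the scatter is expected. For compound 3 the estimated value is 700 nM, with an expected range of 200 nM to 2500 nM. This estimate means an expected 1.3-fold higher number from compound 2 to compound 3 (0.10 log units; within the scatter).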

Compound 3, half-maximal inhibitory concentration: 2120 nM
The estimate for compound 3 lay 3.0-fold (0.48 log units) below the measured number; measured number inside the range.
By their numbers in this assay, from the lowest: compounds 2 and 1 (each within the scatter of the next); then compound 3.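

In this assay there is a 3.8-fold higher number from compound 2 to compound 3 (0.58 log units; beyond the scatter) and a 3.3-fold higher number from compound 1 to compound 3 (0.51 log units; beyond the scatter) when benzamido sits on this aromatic carbon, meta to a large group. Methyl and ethynyl had read alike here, so only this larger group shows that the position responds to its substituent, and the response is modest. Nothing measured bears on why the number rises.

The compounds shown leave open whether the rise follows the added ring or the amide link. They also leave open how acetamido or a simple amine would read at this place.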